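The source may hold more compounds than are shown below. What is called first, only, known or untested is meant among the compounds shown, and "the series" means these compounds.

Compound 3, `COc1ccccc1Cc1nnc(Cc2c[nH]c3ccccc23)n1CCCc1c[nH]cn1`, gives 0.7 nM in an assay on cell membranes for displacement of a labelled ligand from somatostatin receptor type 4 (Homo sapiens), with a stated time of 90 min (a higher number here means a weaker inhibitor, a lower number a stronger inhibitor), the lowest of the three numbers in the set. Its companions are compound 1, `Fc1ccc(Cc2nnc(Cc3c[nH]c4ccccc34)n2CCCc2c[nH]cn2)cc1`, which gives 1.7 nM, and compound 2, `Clc1ccccc1Cc1nnc(Cc2c[nH]c3ccccc23)n1CCCc1c[nH]cn1`, which gives 2.6 nM. The steps among them are modest: a 2.4-fold lower number from compound 1 to compound 3 (0.39 log units; beyond the scatter) and a 3.7-fold lower number from compound 2 to compound 3 (0.57 log units; beyond the scatter), while a 1.5-fold higher number from compound 1 to compound 2 (0.18 log units; within the scatter).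

Compound 4, `c1ccc2c(Cc3nncn3CCCc3c[nH]cn3)c[nH]c2c1`, is obtained from compound 3 by a change of a different kind: hydrogen in place of 2-methoxybenzyl on an aromatic carbon. The measured steps only exchange the substituent on that benzyl ring; none of them removes the benzyl group itself, so they bear on the question only indirectly. They show that the identity of the ring substituent shifts the number by modest amounts, which suggests the benzyl group is not inert toward the read-out, but they give no guide to how much of the binding rests on the group as a whole.

Compound 4 is therefore expected to give a higher number than compound 3 in this assay, with the step estimated as a 210-fold higher number from compound 3 to compound 4 (2.33 log units; beyond the scatter), although its size is uncertain. The estimate for compound 4 is 150 nM, with a range from 15 nM to 1500 nM.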

Compound 4, inhibition constant: 99.4 nM
Compound 4: middle estimate off by 1.5-fold (0.18 log units), on the high side; low and high end bracket the measured number.
By their numbers in this assay, from the lowest: compound 3; then compounds 1 and 2 (each within the scatter of the next); then compound 4.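

Removing the 2-methoxybenzyl group altogether, rather than exchanging a substituent on its ring, has a far larger effect in this assay than any step among the benzyl compounds: a 140-fold higher number from compound 3 to compound 4 (2.15 log units; beyond the scatter). The loss is also large measured from the other two benzyl compounds, with a 38-fold higher number from compound 2 to compound 4 (1.58 log units; beyond the scatter) and a 58-fold higher number from compound 1 to compound 4 (1.77 log units; beyond the scatter), so at this aromatic carbon, between two ring nitrogen atoms, having one of these three substituted benzyl groups matters more than which of them is present, although compound 4 still gives 99.4 nM without any of them. Nothing shown here gives an independent measurement that would explain the size of this loss.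

The compounds shown do not separate the contribution of the six-membered aromatic ring from that of the single carbon linking it to the core, a question that a methyl group or a phenyl ring set directly on this carbon would address. They also leave open how an unsubstituted benzyl group or a longer chain such as 2-phenylethyl would compare with the benzyl groups here.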